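The source may report more compounds than this note shows. Statements on the series, on what has been measured and on what is new or still open speak of the compounds shown alone.

Values so far in a functional assay on NCI-H460 cells (Homo sapiens) for cytotoxicity, read by MTT assay, with a stated time of 48 h (on this read-out higher numbers stand for weaker inhibition and lower numbers for stronger inhibition), all of them limits and not numbers

- compound 1 `COc1ccc(/C=C/C(=O)/C=C/c2cc3ccccc3nc2Cl)cc1` gives > 10000 nM as a limit
- compound 2 `COc1ccc(/C=C/C(=O)/C=C/c2cc3ccccc3nc2Cl)c(OC)c1` gives > 10000 nM as a limit
- compound 3 `COc1ccc(/C=C/C(=O)/C=C/c2cc3ccccc3nc2Oc2ccccc2)cc1OC` gives > 10000 nM as a limit

Compound 1 therefore stands at a limit, with no number to start from, and the series as a whole offers the limit of > 10000 nM in this assay, at which 3 of the 3 values shown sit, and nothing more. Compound 4 `COc1ccc(/C=C/C(=O)/C=C/c2cc3ccccc3nc2Oc2ccc(Br)cc2)cc1` differs from compound 1 by 4-bromophenoxy in place of chloro on an aromatic carbon, with 4-bromophenoxy in place of chloro on an aromatic carbon next to the ring nitrogen. For the measured compounds named here, the one measured step is a step that the two limits leave unreadable from compound 1 to compound 2 and it concerns methoxy in place of hydrogen on an aromatic carbon, so it offers no size to carry over to this change. Going by the values given here, no measured step gives a direction either, so no step beyond the scatter is expected in this assay and compound 4 is expected to stay close to that limit. The estimated step is a number no higher from compound 1 to compound 4 (the limit leaves the size open) and it should be read as an expectation only. For compound 4 the estimate is 10000 nM, with an expected range of 3000 nM to 30000 nM in this assay.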

Compound 4, half-maximal inhibitory concentration: > 10000 nM
Compound 4 ended at the assay's limit; the forecaster's own chance of this, stated with the estimate: 65%; the middle value sits exactly at the limit.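

No step can be read from compound 1 to compound 4, since both stand only at a limit: the limit of > 10000 nM in this assay, at which 4 of the 4 values shown sit.

The compounds shown leave open the size and even the direction of the change from chloro to 4-bromophenoxy, with no number yet to measure from.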